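Exchanging the Ketone Aryl Group of Compound 2

This account rests on a few compounds, and the source may have more. Where it says the series, first, only, none or still open, it means among the compounds named here.

Compound 1, `OB1OCc2ccc(-n3cccc3Sc3ccc(Cl)c(Cl)c3)cc21`, gives > 10 ug/mL.
Compound 2, `Cc1ccccc1C(=O)c1ccn(-c2ccc3c(c2)B(O)OC3)c1`, gives > 10 ug/mL.

Both compounds were tested in an ADME assay on L929 cells (Mus musculus) for cytotoxicity, read by resazurin assay, with a stated time of 72 h; on this read-out lower numbers stand for stronger inhibition and higher numbers for weaker inhibition. The value of compound 1 is a limit of the assay and not a number. The value of compound 2 is likewise a limit and not a number. Within the data shown here, compound 2 therefore stands at the limit of > 10 ug/mL in this assay, at which 2 of the 2 values shown sit, and since no step between measured compounds is available, the known data give no scale for how much any single change moves this read-out. Compound 3, `Cc1ccsc1C(=O)c1ccn(-c2ccc3c(c2)B(O)OC3)c1`, differs from compound 2 by 3-methylthiophen-2-yl in place of 2-methylphenyl on a carbonyl carbon. Because compound 2 gives > 10 ug/mL, the expected step in this assay is a step that the limit leaves unreadable from compound 2 to compound 3, none beyond the scatter. Compound 3 is accordingly estimated at 15 ug/mL, with a range from 7 ug/mL to 40 ug/mL, and most likely this assay will again report only a limit for compound 3.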

Compound 3, half-maximal inhibitory concentration: > 10 ug/mL
Compound 3: no number, only a limit; the forecaster's own chance of this, stated with the estimate: 80%; the middle value lies beyond the limit too.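

Compound 2 and compound 3 are each reported only as a limit in this assay, so no step can be read between them. The compounds shown leave open whether 3-methylthiophen-2-yl in place of 2-methylphenyl on a carbonyl carbon moves this read-out at all.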